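This account rests on a few compounds, and the source may have more. Where it says the series, first, only, none or still open, it means among the compounds named here.

Of the compounds shown here, two have been measured in an assay on COS-7 cells for inhibition of patatin-like phospholipase domain-containing protein 2 (Mus musculus); on this read-out lower numbers stand for stronger inhibition and higher numbers for weaker inhibition. Compound 1, `CCOC(=O)c1cccc(-c2ccsc2)c1`, gives 75000 nM in this assay. Compound 2, `CCOC(=O)Nc1cccc(-c2ccc(N(C)C)cc2)c1`, gives 3000 nM in this assay. Compound 2 thus stands lowest of the two numbers, and the gap up to compound 1 lies well beyond the scatter of repeated measurements.

Compound 3, `CN(C)c1ccc(-c2cccc(NC(=O)C(C)(C)C)c2)cc1`, has not yet been measured. It differs from compound 2 in one place: tert-butyl in place of ethoxy on a carbonyl carbon. The carbonyl group and its amide-type nitrogen stay as they are, so the change is confined to the group on the far side of that carbonyl. For the measured compounds named here, no step between two measured compounds shows what such an exchange does here, so only a guess is possible. The expectation is a small step toward a higher number, one that may stay within the scatter. Compound 3 is therefore expected to give about 5000 nM, between 1500 nM and 20000 nM. That estimate means an expected step of a 1.7-fold higher number from compound 2 to compound 3 (0.22 log units; within the scatter).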

Compound 3, half-maximal inhibitory concentration: > 200000 nM
Compound 3: a limit, no number; the forecaster's own chance of this, stated with the estimate: 15%; at least 40-fold (1.60 log units) between middle value and limit.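

The group on the far side of the carbonyl carries great weight in this assay: with the carbonyl and its amide-type nitrogen unchanged, tert-butyl in place of ethoxy brings an at least 66-fold higher number from compound 2 to compound 3 (1.82 log units; beyond the scatter). Compound 3 gives > 200000 nM, which is a limit of the assay and not a number, so the full size of this step cannot be read. This is the first step between measured compounds in the series, and it shows that one exchange at this place can carry a compound from a measurable number to the limit: the limit of > 200000 nM in this assay, at which 1 of the 3 values shown sits.

The compounds shown leave open what a methoxy group, a longer chain or an amine on the same carbonyl would give. They therefore cannot tell whether the change follows from the ethoxy that leaves, with its oxygen, or from the tert-butyl that enters.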